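The source may hold more compounds than are shown below. What is called first, only, known or untested is meant among the compounds shown, and "the series" means these compounds.

In a functional assay on the whole organism with Rattus norvegicus as the target, with a stated time of 4 h, at a dose of 40 mg/kg by the intraperitoneal route (a lower number here means less inhibition, a higher number more inhibition at the dose given (going by the name of the read-out)), compound 2 `[C-]#[N+]Cc1c(C)nc2c(OCc3ccccc3)cccn12` gives 96%, the highest of the three numbers. Compound 1 `Cc1nc2c(OCc3ccccc3)cccn2c1C#N` gives 25% and compound 3 `CCCCC(=O)OCc1c(C)nc2c(OCc3ccccc3)cccn12` gives 45%, so compound 2 stands a number 51 percentage points lower from compound 2 to compound 3 (beyond the scatter) and a number 71 percentage points higher from compound 1 to compound 2 (beyond the scatter). Compound 4 `Cc1nc2c(OCc3ccccc3)cccn2c1C` has not yet been measured; it differs from compound 2 by a hydrogen atom in place of a group of 2 heavy atoms (1 carbon, 1 nitrogen; no ring), on a saturated chain carbon bound to an aromatic carbon. Among the measured compounds shown here, two measured steps bear on this change, both altering the group on that same saturated chain carbon: the step of a number 51 percentage points lower from compound 2 to compound 3 (beyond the scatter) and the step of a number 71 percentage points higher from compound 1 to compound 2 (beyond the scatter). Each time the isocyanomethyl arrangement of compound 2 was exchanged for something else, the inhibition fell by a large amount, and compound 4 carries only a hydrogen there. A large drop is therefore expected, a number 61 percentage points lower from compound 2 to compound 4 (beyond the scatter). Compound 4 is estimated to give about 35% in this assay, with a plausible range from 10% to 65%.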

Compound 4, a percentage reported as inhibition, in the whole organism at one dose (the size of the read-out at that dose, not a potency): 99%
The estimate for compound 4 lay 64 percentage points below the measured number; the measured number lies above the stated range.
By their numbers in this assay, from the lowest: compound 1; then compound 3; then compounds 2 and 4 (each within the scatter of the next).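

In this assay, a hydrogen atom can stand in place of the group of 2 heavy atoms on the saturated chain carbon bound to an aromatic carbon without a change beyond the scatter, with the step being a number 3 percentage points higher from compound 2 to compound 4 (within the scatter), so that group is not needed for the high inhibition. The lower number of compound 3 therefore goes with the presence of (butylcarbonyl)oxy on that carbon, since hydrogen in its place gives a number 54 percentage points higher from compound 3 to compound 4 (beyond the scatter). On the aromatic carbon, methyl in place of cyano gives a number 74 percentage points higher from compound 1 to compound 4 (beyond the scatter), so the low number of compound 1 goes with cyano at that place.

As far as these compounds go, whether a hydroxyl or an amine on the saturated chain carbon would match hydrogen or fall towards the (butylcarbonyl)oxy ester remains open. Nothing given here explains these differences.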